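A few compounds are considered here, and "the series" means these few. Any claim that something is new, unique, unknown or untested is made for them only; others in the source may bear on it.

Measured compounds in a functional assay on HT-29 cells (Homo sapiens) for inhibition, read by MTT assay; a lower number here means a stronger inhibitor, a higher number a weaker inhibitor:
- compound 1 `COc1cc2c(Oc3ccc(NC(=O)NN4C(=O)CSC4c4cccc(F)c4F)cc3)ccnc2cc1OC1CCN(C(=O)NC(C)C)CC1` gives 790 nM
- compound 2 `COc1cc2c(Oc3ccc(NC(=O)NN4C(=O)CSC4c4ccccc4F)cc3)ccnc2cc1OC1CCN(C(=O)NC(C)C)CC1` gives 410 nM
- compound 3 `COc1cc2c(Oc3ccc(NC(=O)NN4C(=O)CSC4c4ccc(F)cc4F)cc3)ccnc2cc1OC1CCN(C(=O)NC(C)C)CC1` gives 950 nM

Compound 3 has the highest number of the three. Its gap to compound 1 is small, a 1.2-fold higher number from compound 1 to compound 3 (0.08 log units; within the scatter), while its gap to compound 2 is larger, a 2.3-fold higher number from compound 2 to compound 3 (0.36 log units; beyond the scatter).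

Compound 4 `COc1cc2c(Oc3ccc(NC(=O)NN4C(=O)CSC4c4cccc(F)c4)cc3)ccnc2cc1OC1CCN(C(=O)NC(C)C)CC1` differs from compound 3 in one place: 3-fluorophenyl in place of 2,4-difluorophenyl on a saturated ring carbon. Among the compounds with values here, two measured steps bear on this. Taking one fluoro away, a 1.9-fold lower number from compound 1 to compound 2 (0.28 log units; within the scatter), lowered the number a little. Adding one fluoro, a 2.3-fold higher number from compound 2 to compound 3 (0.36 log units; beyond the scatter), raised it modestly. Moving between the two difluoro patterns, a 1.2-fold higher number from compound 1 to compound 3 (0.08 log units; within the scatter), changed nothing beyond the scatter. Compound 4 carries a single fluoro, as does compound 2, but at a different position, so a modest drop toward the value of compound 2 is the expectation, though the position shift adds uncertainty.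

Compound 4 is therefore estimated at 500 nM in this assay, with a range from 250 nM to 1000 nM, meaning an expected step of a 1.9-fold lower number from compound 3 to compound 4 (0.28 log units; within the scatter).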

Compound 4, half-maximal inhibitory concentration: 670 nM
Compound 4: the middle estimate sits 1.3-fold (0.13 log units) below what was measured; low and high end bracket the measured number.
By their numbers in this assay, from the lowest: compounds 2, 4, 1 and 3 (each within the scatter of the next, the first and the last beyond it).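

In this assay, the single fluoro of the 3-fluorophenyl group leaves compound 4 within the scatter of all three earlier compounds: a 1.4-fold lower number from compound 3 to compound 4 (0.15 log units; within the scatter), a 1.6-fold higher number from compound 2 to compound 4 (0.21 log units; within the scatter) and a 1.2-fold lower number from compound 1 to compound 4 (0.07 log units; within the scatter). The number of fluoro groups therefore does not sort these compounds, as compound 4, with one fluoro, cannot be told apart from either difluorophenyl compound, and only compound 2 and compound 3 stand beyond the scatter of each other. Adding a fluoro can now be read twice, and the two readings cannot be told apart either: the same change on two cores in this assay, a 2.3-fold higher number (0.36 log units; beyond the scatter) from compound 2 to compound 3 and a 1.2-fold higher number (0.07 log units; within the scatter) from compound 4 to compound 1, 2.0-fold (0.29 log units) apart, within the scatter of two such steps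

The compounds shown leave open what a different group on this phenyl ring, such as chloro, methoxy or a nitrile, would do to the number. They also leave open whether an amine or a carboxylic acid there would move it beyond the scatter.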